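Chloro in Place of Methyl on Compound 2

A few compounds are considered here, and "the series" means these few. Any claim that something is new, unique, unknown or untested is made for them only; others in the source may bear on it.

Measured in a functional assay on HeLa cells (Homo sapiens) for inhibition; on this read-out higher numbers stand for weaker inhibition and lower numbers for stronger inhibition:
compound 1 (`COC(=O)C(C(=O)OC)C1CC(=O)C=CC12OCC(=O)N2Cc1cccc(Cl)c1`) gives 340 nM
compound 2 (`CCSC1CC(=O)CC(SCC)C12OCC(=O)N2Cc1ccc(C)cc1`) gives 2410 nM

Compound 2 holds the higher of the two numbers in this assay. Compound 3 (`CCSC1CC(=O)CC(SCC)C12OCC(=O)N2Cc1ccc(Cl)cc1`) has not yet been measured and differs from compound 2 in one place: chloro in place of methyl on an aromatic carbon, para to a large group. Going by the values given here, no measured pair shows this change, so only a small move toward lower numbers in this assay is expected, probably none beyond the scatter. The expected change is a 1.3-fold lower number from compound 2 to compound 3 (0.10 log units; within the scatter). For compound 3 the estimated value is 1900 nM, within a range of 750 nM to 4800 nM.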

Compound 3, half-maximal inhibitory concentration: 3920 nM
The estimate for compound 3 lay 2.1-fold (0.31 log units) below the measured number, and the stated range covers the measured number.
By their numbers in this assay, from the lowest: compound 1; then compounds 2 and 3 (each within the scatter of the next).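

In this assay the change from 4-methylphenyl to 4-chlorophenyl gives a 1.6-fold higher number from compound 2 to compound 3 (0.21 log units; within the scatter) and so shows that chloro can stand in place of methyl at this position without a step beyond the scatter. Going by these compounds alone, this is the first pair here that differs in one place, and it reads this position alone on the shared core. Nothing at hand explains the result.

Going by these compounds, whether an amine, a methoxy group or a carboxylic acid at this position would give a step beyond the scatter stays open. On these data alone, whether the same change would behave alike on another core also stays open.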